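Notes on compound 1 and its methyl analogue

A few compounds are considered here, and "the series" means these few. Any claim that something is new, unique, unknown or untested is made for them only; others in the source may bear on it.

Compound 1 `CNC(=O)c1cc(C(=O)N[C@H]2[C@@H]3COC[C@@H]32)cc2c1OC[C@@]2(CO)c1ccccc1` gives >= 202 ug/mL (a limit)
Compound 2 `CNC(=O)c1cc(C(=O)N[C@H]2[C@@H]3COC[C@@H]32)cc2c1O[C@H](CF)[C@H]2c1ccccc1` gives >= 206 ug/mL (a limit)
Compound 3 `CNC(=O)c1cc(C(=O)N[C@H]2[C@@H]3COC[C@@H]32)cc2c1OC[C@@]2(C)c1ccccc1` is not yet measured

In a physicochemical assay for solubility (on this read-out lower numbers stand for lower solubility and higher numbers for higher solubility), compound 1 gives only a limit (>= 202 ug/mL) and no number. Compound 2 likewise gives only a limit (>= 206 ug/mL) and no number.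

Compound 3 keeps the core of compound 1 and differs from it in one place (hydrogen in place of hydroxy on a saturated chain carbon bound to a saturated ring carbon). This is hydrogen in place of hydroxy on a saturated chain carbon bound to a saturated ring carbon, or hydroxymethyl to methyl when cut one bond further out.

Among the measured compounds shown here, no measured step covers this change. A modest fall is expected in this assay for compound 3, of a size not far beyond the usual scatter, and another limit remains possible. This expectation starts from the limit of compound 1 (>= 202 ug/mL) and from the structural difference alone. The estimated step runs (an at least 1.3-fold lower number from compound 1 to compound 3 (0.12 log units; that floor lies within the scatter)) and is counted from that limit. The estimate for compound 3 is 150 ug/mL with an expected range of 60 ug/mL to 220 ug/mL until a measurement is available.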

Compound 3, solubility: >= 147 ug/mL
Compound 3: no number, only a limit; the forecaster's own chance of this, stated with the estimate: 40%; the middle value lies beyond the limit too.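

In this assay compound 3 gives >= 147 ug/mL, which is a limit and not a number. Compound 1 gives >= 202 ug/mL, also a limit. Among the compounds shown here, no step from compound 1 to compound 3 can be read from these two limits. The compounds shown leave open whether hydroxymethyl to methyl shifts the read-out in this assay, and by how much.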